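Nucleoside series: cytotoxicity of a hydroxyethylsulfanyl analogue

The source may report more compounds than this note shows. Statements on the series, on what has been measured and on what is new or still open speak of the compounds shown alone.

Measured compounds:
- compound 1 `CN(Cc1ncnc2c1ncn2[C@@H]1O[C@H](CO)[C@@H](O)[C@H]1O)c1ccccc1`: 21000 nM
- compound 2 `OC[C@H]1O[C@@H](n2cnc3c(Cn4ccc5ccccc54)ncnc32)[C@H](O)[C@@H]1O`: > 250000 nM
- compound 3 `OC[C@H]1O[C@@H](n2cnc3c(Cn4cccn4)ncnc32)[C@H](O)[C@@H]1O`: > 250000 nM

Among the compounds with values here, compound 1 is the only member of the set with a measured number in a functional assay on Huh-7 cells (Homo sapiens) for cytotoxicity, read by MTT assay, with a stated time of 3 days; a lower number here means that less compound is tolerated, a higher number that more compound is tolerated. Compound 2 reaches only a limit of the assay, > 250000 nM. Compound 3 likewise sits at a limit, > 250000 nM. So compound 1 is the most cytotoxic compound shown, and the two other values are limits (the limit of > 250000 nM in this assay, at which 2 of the 3 values shown sit).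

Compound 4 `OCCSCc1ncnc2c1ncn2[C@@H]1O[C@H](CO)[C@@H](O)[C@H]1O` carries the change ((2-hydroxyethyl)sulfanyl in place of methyl(phenyl)amino on a saturated chain carbon bound to an aromatic carbon).

Within the data shown here, two measured steps bear on it, both at the same place of the core: an at least 11-fold higher number from compound 1 to compound 2 (1.07 log units; beyond the scatter), and an at least 11-fold higher number from compound 1 to compound 3 (1.07 log units; beyond the scatter). In both, removing methyl(phenyl)amino from that carbon made the cells tolerate more compound. The group entering in compound 4 is smaller and bears a hydrogen-bond donor rather than a second ring, so the same direction is expected, though it may fall short of the limit.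

Compound 4 is therefore expected to give 120000 nM (range 30000 nM to 250000 nM) in this assay, which would be a 5.7-fold higher number from compound 1 to compound 4 (0.76 log units; beyond the scatter).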

Compound 4, half-maximal cytotoxic concentration: > 100000 nM
Compound 4: a limit, no number (the forecaster's own chance of this, stated with the estimate: 50%); the middle value does not contradict the limit.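

In this assay compound 4 reaches only a limit, not a number: the limit of > 100000 nM in this assay, at which 1 of the 4 values shown sits.

Placing (2-hydroxyethyl)sulfanyl on the saturated chain carbon bound to an aromatic carbon gives an at least 4.7-fold higher number from compound 1 to compound 4 (0.67 log units; beyond the scatter), so the direction seen with 1H-indol-1-yl and 1H-pyrazol-1-yl also holds for a group with no ring. Methyl(phenyl)amino remains the only group here with a measured number, and the steps among compound 2, compound 3 and compound 4 cannot be read, as both ends of each are limits.

The compounds shown leave open whether the lower number of compound 1 goes with the phenyl ring or with the amine nitrogen of methyl(phenyl)amino. Dimethylamino and phenylsulfanyl on the same carbon would separate the two.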